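Furan for thiophene on the saturated ring carbon

This account rests on a few compounds, and the source may have more. Where it says the series, first, only, none or still open, it means among the compounds named here.

Measured so far in an assay on HeLa cells for displacement of a labelled ligand from adenosine receptor A3 (Homo sapiens), read by radioligand binding, with a stated time of 180 min, tested at 1 uM; a lower number here means less inhibition, a higher number more inhibition at the concentration tested (going by the name of the read-out):
compound 1 `CC(C)OC(=O)C1=C(C(F)(F)F)NC(=O)NC1c1ccsc1`: 3%
compound 2 `CCOC(=O)C1=C(C(F)(F)F)NC(=O)NC1c1ccoc1`: 1%
compound 3 `CC1=C(C(=O)OC(C(F)(F)F)C(F)(F)F)C(c2ccco2)NC(=O)N1`: 2%

All three numbers sit close together: compound 1 lies within the usual scatter of both compound 2 and compound 3, so the three cannot be placed in any order. Compound 4 `CC(C)OC(=O)C1=C(C(F)(F)F)NC(=O)NC1c1ccco1` is the next member. It differs from compound 1 in one place: furan-2-yl in place of thiophen-3-yl on a saturated ring carbon. For the measured compounds named here, no direct step between two measured compounds isolates this exchange, but compound 2 and compound 3 already carry the furan-2-yl group, and in this assay compound 2 gives 1% while compound 3 gives 2%. Compound 4 is therefore expected to give 2%, within -6% to 10%. The expected step of a number 1 percentage points lower from compound 1 to compound 4 (within the scatter) is estimated to stay within the scatter.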

Compound 4, a percentage reported as inhibition, at one concentration (the size of the read-out at that concentration, not a potency): 5%
Beside the measured number, compound 4's estimate is 3 percentage points below it; measured number inside the range.
By their numbers in this assay, from the lowest: compounds 2, 3, 1 and 4 (each within the scatter of the next).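

For the compounds shown here, with the isopropoxycarbonyl group held constant, the first direct reading at this saturated ring carbon in this assay comes from exchanging thiophen-3-yl for furan-2-yl (a number 2 percentage points higher from compound 1 to compound 4 (within the scatter)). This step separates neither ring from the other, so at the concentration tested the read-out does not distinguish these two five-membered aromatic rings here. No measurement offered here bears on this result.

The compounds shown leave open whether a phenyl ring or a cyclohexyl group on this carbon would read differently. They also leave open whether the same exchange would read alike beside an ethoxycarbonyl group.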